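The source may report more compounds than this note shows. Statements on the series, on what has been measured and on what is new or still open speak of the compounds shown alone.

Compound 1: `CCOC(=O)c1c(-c2cccc(F)c2)[nH]c2cc(OC)ccc2c1=O` — > 21500 nM
Compound 2: `CCOC(=O)c1c(-c2cccc(OC)c2)[nH]c2cc(OC)c(F)cc2c1=O` — > 21500 nM

Both measured compounds sit at the edge of what an ADME assay on HepG2 cells (Homo sapiens) for cytotoxicity, read by luminescence, with a stated time of 72 h (a higher number here means that more compound is needed for the effect, a lower number that less compound is needed), can report. For compound 1 the reading of > 21500 nM is a limit of the assay, not a number. For compound 2 the reading of > 21500 nM is likewise a limit. Compound 2 therefore stands at the top end of the shown numbers, where every value shown is a limit: the limit of > 21500 nM in this assay, at which 2 of the 2 values shown sit.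

Compound 3, `CCOC(=O)c1c(-c2cccc(F)c2)[nH]c2cc(OC)c(F)cc2c1=O`, shares the core of compound 2 and differs from it in one place: fluoro in place of methoxy on an aromatic carbon The methoxy leaves from an aromatic carbon of a six-membered aromatic ring of carbon only, and a fluoro enters there, turning a 3-methoxyphenyl into a 3-fluorophenyl. Compound 1 already carries that 3-fluorophenyl and also reads only as a limit in this assay.

Within the data shown here, with no measured step to lean on, the expected step from compound 2 to compound 3 is a step that the limit leaves unreadable from compound 2 to compound 3, none beyond the scatter. Compound 3 is thus estimated to give 30000 nM in this assay, between 15000 nM and 100000 nM, most probably again only as a limit.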

Compound 3, half-maximal effective concentration: > 21500 nM
Compound 3 was reported as a limit; the forecaster's own chance of this, stated with the estimate: 85%; the middle value does not contradict the limit.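

Among these compounds, compound 3 is again a limit and not a number, like compound 1 and compound 2, so no step from either of them to compound 3 can be read in this assay: the limit of > 21500 nM in this assay, at which 3 of the 3 values shown sit. The compounds shown leave open how far each lies past that limit, and whether these changes alter the reading at all.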